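Iodo in Place of Ethynyl on a Shared Nucleoside Core

The compounds below may be only part of what the source reports. "The series", "measured", "known", "first", "only" and "open" are said of these compounds alone.

Four compounds were compared in a functional assay on HL-60 cells (Homo sapiens) for antiproliferative activity, read by XTT assay, with a stated time of 72 h; a higher number here means a weaker inhibitor, a lower number a stronger inhibitor. Compound 1 `C#Cc1cn([C@@H]2O[C@H](CO)[C@@H](O)[C@H]2O)c2ncnc(NC)c12` gave 9060 nM in this assay. Compound 2 `C#Cc1cn([C@@H]2O[C@H](CO)[C@@H](O)[C@H]2O)c2nc(C)nc(N)c12` differs from compound 1 in its core; the difference between the two cores is not broken down here. Compound 2 reached only > 20000 nM in this assay, which is a limit of the assay and not a number. Compound 3 `Cc1nc(N)c2c(I)cn([C@@H]3O[C@H](CO)[C@@H](O)[C@H]3O)c2n1` carries the change iodo in place of ethynyl on an aromatic carbon relative to compound 2. In this assay compound 3 gave 2050 nM. That change made an at least 9.7-fold lower number from compound 2 to compound 3 (0.98 log units; beyond the scatter), a step whose true size is hidden by the limit of > 20000 nM in this assay, at which 1 of the 3 values shown sits.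

Compound 4 `CNc1ncnc2c1c(I)cn2[C@@H]1O[C@H](CO)[C@@H](O)[C@H]1O` is not yet measured and stands to compound 1 as compound 3 stands to compound 2: the same change iodo in place of ethynyl on an aromatic carbon on the same place. Given that compound 2 to compound 3 gave an at least 9.7-fold lower number from compound 2 to compound 3 (0.98 log units; beyond the scatter), the author expects the step from compound 1 to compound 4 in this assay to be a 6.0-fold lower number from compound 1 to compound 4 (0.78 log units; beyond the scatter). Compound 4 is therefore estimated at 1500 nM in this assay, within a range of 400 nM to 6000 nM.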

Compound 4, half-maximal inhibitory concentration: > 20000 nM
Compound 4 ended at the assay's limit (the forecaster's own chance of this, stated with the estimate: 3%); middle value at least 13-fold (1.12 log units) from the limit.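

Carried to the core of compound 1, the change iodo in place of ethynyl on an aromatic carbon gave an at least 2.2-fold higher number from compound 1 to compound 4 (0.34 log units; beyond the scatter), so in this assay the improvement seen on the other core did not transfer, and the two steps run in opposite directions: the same change on two cores in this assay, an at least 9.7-fold lower number (0.98 log units; beyond the scatter) from compound 2 to compound 3 and an at least 2.2-fold higher number (0.34 log units; beyond the scatter) from compound 1 to compound 4, at least 21-fold (1.33 log units) apart, beyond the scatter of two such steps. Compound 4 gives > 20000 nM, which is a limit of the assay and not a number, so the true size of both steps stays hidden: the limit of > 20000 nM in this assay, at which 2 of the 4 values shown sit. The two pairs show that the outcome of this change depends on the core that carries it, but they do not show which difference between the cores sets the steps apart, and they give no rule for any other core.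

The compounds shown leave open how a bromo group, a nitrile or a longer chain in the same place would behave on these two cores. They also leave open whether a third core would follow compound 3 or compound 4.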